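Bromo in place of hydroxy on the aryl urea

This account rests on a few compounds, and the source may have more. Where it says the series, first, only, none or still open, it means among the compounds named here.

Of the compounds shown here, three built on one shared core have been measured in a functional assay on MCF7 cells (Homo sapiens) for inhibition, read by MTT assay, with a stated time of 72 h; a higher number here means a weaker inhibitor, a lower number a stronger inhibitor. Compound 1 `COc1cc(NC(C)CCCNC(=O)NNC(=O)Nc2cc(C(F)(F)F)cc(C(F)(F)F)c2)c2ncccc2c1` gives 2400 nM, compound 2 `COc1cc(NC(C)CCCNC(=O)Nc2ccc(C(F)(F)F)cc2)c2ncccc2c1` gives 1900 nM, and compound 3 `COc1cc(NC(C)CCCNC(=O)Nc2ccc(O)cc2)c2ncccc2c1` gives 5200 nM. Compound 3 thus has the highest number of the three, with compound 1 the nearest and compound 2 the furthest below it, both gaps beyond the scatter.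

Compound 4 `COc1cc(NC(C)CCCNC(=O)Nc2ccc(Br)cc2)c2ncccc2c1` differs from compound 3 at one aromatic carbon: bromo in place of hydroxy on an aromatic carbon. Among the measured compounds shown here, only one measured step speaks to this position. There, hydroxy in place of trifluoromethyl on an aromatic carbon gave a 2.7-fold higher number from compound 2 to compound 3 (0.44 log units; beyond the scatter), a modest rise beyond the scatter. Compound 4 removes that same hydroxy and places bromo there instead, and the change is expected to undo a part of that rise, so that in this assay a modest fall from compound 3 is expected, of about a 2.1-fold lower number from compound 3 to compound 4 (0.32 log units; beyond the scatter). For the measured compounds named here, no bromo-bearing compound has been measured, so this rests on the single step from compound 2 to compound 3 alone. Compound 4 is therefore estimated at 2500 nM, within a range from 1200 nM to 5500 nM.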

Compound 4, half-maximal inhibitory concentration: 2600 nM
The estimate for compound 4 lay 1.0-fold (0.02 log units) below the measured number, within the range that was stated.
By their numbers in this assay, from the lowest: compounds 2, 1, 4 and 3 (each within the scatter of the next, the first and the last beyond it).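

In this assay the exchange of hydroxy for bromo comes to a 2.0-fold lower number from compound 3 to compound 4 (0.30 log units; within the scatter) and does not separate the two groups, even though it removes the hydrogen-bond donor and the hydrogen-bond acceptor counted for hydroxy. Bromo set against trifluoromethyl gives a 1.4-fold higher number from compound 2 to compound 4 (0.14 log units; within the scatter), so compound 4 cannot be told apart from either compound 2 or compound 3, while those two remain beyond the scatter of each other; the earlier compounds showed only that one gap at this position, and a single bromine atom now sits inside it without clearly joining either end. Nothing measured on these groups is available to account for these numbers.

What the compounds shown leave open is whether any group on this aromatic carbon can move the number further than the gap seen so far, in either direction, since three groups span only a narrow stretch of values. A fluoro, a nitrile, an amine or a carboxylic acid in the same place would test this, as would a plain hydrogen.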